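The source may hold more compounds than are shown below. What is called first, only, known or untested is meant among the compounds shown, and "the series" means these compounds.

Measured in a functional assay on MGC-803 cells (Homo sapiens) for antiproliferative activity, read by MTT assay, with a stated time of 72 h; on this read-out lower numbers stand for stronger inhibition and higher numbers for weaker inhibition:
- Compound 1 `CCCSc1nc(N/N=C/c2ccc(C)cc2)c2nnn(Cc3ccccc3)c2n1`: > 64000 nM, a limit of the assay
- Compound 2 `CCCSc1nc(N/N=C/c2ccc(N(C)C)cc2)c2nnn(Cc3ccccc3)c2n1`: 13100 nM
- Compound 3 `CCCSc1nc(N/N=C(\C)c2ccccc2)c2nnn(Cc3ccccc3)c2n1`: 25400 nM

Compound 3, at 25400 nM, lies within the usual scatter of compound 2, at 13100 nM. The reading for compound 1 is only a limit.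

Compound 4 `CCCSc1nc(N/N=C/c2ccccc2)c2nnn(Cc3ccccc3)c2n1` differs from compound 3 by one change, on a nitrogen on an aromatic ring: a group of 8 heavy atoms (7 carbon, 1 nitrogen; one six-membered aromatic ring of carbon only) in place of a group of 9 heavy atoms (8 carbon, 1 nitrogen; one six-membered aromatic ring of carbon only), on a nitrogen on an aromatic ring. Within the data shown here, two measured steps bear on it. The closer is an at least 2.5-fold lower number from compound 1 to compound 3 (0.40 log units; beyond the scatter), an exchange at that same place between two groups of 9 heavy atoms. The other is an at least 4.8-fold lower number from compound 1 to compound 2 (0.68 log units; beyond the scatter), with dimethylamino in place of methyl on an aromatic carbon. On these data alone, both lie beyond the scatter and both start from a limit, so their full size remains open. Compound 4 carries no dimethylamino group, so the gain in an at least 4.8-fold lower number from compound 1 to compound 2 (0.68 log units; beyond the scatter) offers it no support, and a small move towards weaker inhibition is expected in this assay, within the scatter. The expected change is a 1.4-fold higher number from compound 3 to compound 4 (0.15 log units; within the scatter). For compound 4 the estimated value is 36000 nM, with an expected range from 14000 nM to 85000 nM.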

Compound 4, half-maximal inhibitory concentration: > 64000 nM
Compound 4 gave a limit, no number; the forecaster's own chance of this, stated with the estimate: 30%; at least 1.7-fold (0.24 log units) between middle value and limit.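

In this assay compound 4 stands at a limit of the assay, not at a number: the limit of > 64000 nM in this assay, at which 2 of the 4 values shown sit.

On a nitrogen on an aromatic ring, the group of 8 heavy atoms in place of the group of 9 heavy atoms gives an at least 2.5-fold higher number from compound 3 to compound 4 (0.40 log units; beyond the scatter), so the smaller of these two groups goes with weaker inhibition at this place. Hydrogen in place of dimethylamino on an aromatic carbon gives an at least 4.8-fold higher number from compound 2 to compound 4 (0.68 log units; beyond the scatter), showing that compound 2 owes its measurable inhibition to the dimethylamino group on the otherwise unchanged structure, while the step between the two compounds at the limit cannot be read.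

On these data alone, whether another amine or a carboxylic acid in place of dimethylamino on an aromatic carbon would keep this inhibition remains open. So does the effect of an ethyl group in place of the methyl group that separates compound 3 from compound 4.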